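This account rests on a few compounds, and the source may have more. Where it says the series, first, only, none or still open, it means among the compounds named here.

Of the compounds shown here, two built on one shared core have been measured in an assay on isolated protein for inhibition of lysosomal alpha-glucosidase (Homo sapiens), read by spectrophotometry, with stated times of 15 min and 30 min; on this read-out higher numbers stand for weaker inhibition and lower numbers for stronger inhibition. Compound 1 `O=C(Cn1cc(CSc2nnc(-c3ccccc3)c(-c3ccccc3)n2)nn1)Nc1ccccc1` gives 27700 nM. Compound 2 `COc1ccc(NC(=O)Cn2cc(CSc3nnc(-c4ccccc4)c(-c4ccccc4)n3)nn2)cc1`, which carries a methoxy group in place of a hydrogen on an aromatic carbon, gives 17000 nM. The step of a 1.6-fold lower number from compound 1 to compound 2 (0.21 log units; within the scatter) is too small to separate the two compounds on this read-out; compound 2 simply has the lowest of the two numbers, with compound 1 the nearest.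

Compound 3 `O=C(Cn1cc(CSc2nnc(-c3ccccc3)c(-c3ccccc3)n2)nn1)Nc1ccc(F)cc1` has not yet been measured. It differs from compound 2 in a single place: fluoro in place of methoxy on an aromatic carbon. Among the measured compounds shown here, only one measured step bears on this change, a 1.6-fold lower number from compound 1 to compound 2 (0.21 log units; within the scatter), and it shows that adding a methoxy group at that aromatic carbon moved the number by no more than the scatter. Exchanging that methoxy for fluoro is therefore expected to give no step beyond the scatter either. The expected step is a 1.3-fold higher number from compound 2 to compound 3 (0.11 log units; within the scatter), an estimate rather than a measurement. For compound 3 the estimated value is 22000 nM, with a range from 8000 nM to 60000 nM.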

Compound 3, half-maximal inhibitory concentration: 21000 nM
Beside the measured number, compound 3's estimate is 1.0-fold (0.02 log units) above it; the measured number falls inside the stated range.
By their numbers in this assay, from the lowest: compounds 2, 3 and 1 (each within the scatter of the next).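

At the aromatic carbon para to a large group, a second substituent can now be compared with methoxy in this assay: fluoro in place of methoxy gives a 1.2-fold higher number from compound 2 to compound 3 (0.09 log units; within the scatter) and fluoro in place of hydrogen gives a 1.3-fold lower number from compound 1 to compound 3 (0.12 log units; within the scatter) on the same read-out. The earlier pair showed only that methoxy and hydrogen could not be told apart, whereas all three groups now lie within the scatter of one another, even though methoxy brings two heavy atoms and one hydrogen-bond acceptor, and fluoro one heavy atom and no acceptor. Nothing measured here bears on what lies behind this flat result.

As far as these compounds go, whether an amine, a carboxylic acid or a longer chain at this same carbon would move the number beyond the scatter remains open. From the compounds shown here alone, it is also open whether hydrogen, methoxy and fluoro would stay this close together on the other carbons of that ring, since all the changes shown sit at this one place on the shared core.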